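The source may report more compounds than this note shows. Statements on the series, on what has been measured and on what is new or still open speak of the compounds shown alone.

Of the compounds shown here, two built on one shared core have been tested in an assay on isolated protein for displacement of a labelled ligand from metabotropic glutamate receptor 5 (Homo sapiens), with a stated time of 60 min, tested at 1 uM; a higher number here means more inhibition at the concentration tested (going by the name of the read-out), a lower number less inhibition. Compound 1 `CC1CCN(c2c(S(=O)(=O)c3cc(Cl)cc(Cl)c3)cnc3c(F)cccc23)CC1` gives 82%. Among the measured compounds shown here, compound 2 `CC1CCN(c2c(S(=O)(=O)c3ccc(F)c(F)c3)cnc3c(F)cccc23)CC1` gives 93%, the highest of the two numbers, and the single measured step, a number 11 percentage points higher from compound 1 to compound 2 (beyond the scatter), is modest yet beyond the scatter. Compound 3 `CC1CCN(c2c(S(=O)(=O)c3ccc(F)c(Cl)c3)cnc3c(F)cccc23)CC1` has not been measured. It differs from compound 2 in one place: chloro in place of fluoro on an aromatic carbon. The measured step bears on this change only loosely: it exchanged both halogens at once, chloro for fluoro, and lifted the read-out by a modest amount. Putting one chloro back where compound 2 carries fluoro may therefore cost a small part of that gain, or nothing beyond the scatter. For compound 3 the expected value in this assay is 88%, with a range from 76% to 96%. The step this estimate implies, a number 5 percentage points lower from compound 2 to compound 3 (within the scatter), is expected to stay small.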

Compound 3, a percentage reported as inhibition, at one concentration (the size of the read-out at that concentration, not a potency): 95%
Compound 3: middle estimate off by 7 percentage points, on the low side, within the range that was stated.
By their numbers in this assay, from the lowest: compound 1; then compounds 2 and 3 (each within the scatter of the next).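

In this assay, the exchange of fluoro for chloro on this aromatic carbon, ortho to a fluoro group, gives a number 2 percentage points higher from compound 2 to compound 3 (within the scatter), so at this position the two halogens cannot be told apart. The earlier step replaced 3,5-dichlorophenyl with 3,4-difluorophenyl, changing both halogens at once, whereas a number 13 percentage points higher from compound 1 to compound 3 (beyond the scatter) shows that the higher number can be kept with one chloro still on the ring, so the presence of chloro alone does not set compound 1 apart. Nothing available explains these numbers.

The compounds shown leave open how a methoxy group, a nitrile or plain hydrogen would read on this carbon. A read-out at one concentration also leaves open whether compound 2 and compound 3 would separate in a full potency measurement.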